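A Dimethoxyphenyl Swap on a Weak Sulfonyl Chalcone

The source may report more compounds than this note shows. Statements on the series, on what has been measured and on what is new or still open speak of the compounds shown alone.

Measured so far:
compound 1 `O=C(/C(=C\c1ccc(Cl)cc1)S(=O)(=O)c1ccc(Br)cc1)c1ccc(Br)cc1` gives 50000 nM in a functional assay on DU-145 cells (Homo sapiens) for inhibition, read by trypan blue exclusion, with a stated time of 96 h; a lower number here means a stronger inhibitor of growth, a higher number a weaker inhibitor of growth
compound 2 `CN(C)c1ccc(/C=C(/SCc2ccc(Cl)cc2)C(=O)c2ccc(C(=O)O)cc2)cc1` gives 1000 nM in this assay
compound 3 `Cc1ccc(S/C(=C/c2c(F)c(F)c(F)c(F)c2F)C(=O)c2ccc(Cl)cc2)cc1` gives 25000 nM in this assay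

Compound 1 has the highest number of the three. Its gap to compound 3 lies within the scatter, so the two cannot be ranked; its gap to compound 2 lies beyond the scatter, so compound 2 is the clearly stronger growth inhibitor of that pair.

Compound 4 `COc1cccc(OC)c1/C=C(\C(=O)c1ccc(Br)cc1)S(=O)(=O)c1ccc(Br)cc1` is compound 1 with one change: 2,6-dimethoxyphenyl in place of 4-chlorophenyl on a double-bonded chain carbon bound to a double-bonded chain carbon

Within the data shown here, no measured pair isolates this change, so the expectation rests on compound 1 alone. The step of a 1.7-fold lower number from compound 1 to compound 4 (0.22 log units; within the scatter) is expected to be small, leaning toward a lower number but not clearly beyond the scatter. Compound 4 is therefore estimated at 30000 nM, with a range from 8000 nM to 100000 nM.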

Compound 4, concentration for 50% growth inhibition: 10000 nM
For compound 4 the middle estimate is 3.0-fold (0.48 log units) above the measured one, within the range that was stated.
By their numbers in this assay, from the lowest: compound 2; then compound 4; then compounds 3 and 1 (each within the scatter of the next).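

Among these compounds, earlier compounds offered no pair that varied this position, and here the swap to 2,6-dimethoxyphenyl gives a 5.0-fold lower number from compound 1 to compound 4 (0.70 log units; beyond the scatter) in this assay. The group on this double-bonded chain carbon therefore affects growth inhibition, even with the rest of the core of compound 1 kept unchanged. No evidence shown explains this step.

Among the compounds shown here, whether both methoxy groups are needed remains open with only this one swap. So does the effect of a 2-methoxyphenyl or a 2,6-dichlorophenyl at the same place.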